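This account rests on a few compounds, and the source may have more. Where it says the series, first, only, none or still open, it means among the compounds named here.

In an ADME assay on MT4 cells (Homo sapiens) for cytotoxicity, read by MTT assay (on this read-out higher numbers stand for lower toxicity in this test and lower numbers for higher toxicity in this test), compound 1 `O=c1cc(Cc2c(F)cccc2F)nc(SCc2ccccc2)[nH]1` gives > 73000 nM, which is a limit of the assay and not a number. Compound 2 `Cc1c(Cc2c(F)cccc2F)nc(SCc2ccc([N+](=O)[O-])cc2)[nH]c1=O` gives > 37000 nM, also a limit. Compound 3 `Cc1ccc(CSc2nc(Cc3c(F)cccc3F)c(C)c(=O)[nH]2)c(C)c1` gives > 65000 nM, again a limit. Compound 3 therefore has no exact place on the numbers shown, and the three compounds cannot be put in order.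

Compound 4 `Cc1c(Cc2c(F)cccc2F)nc(SCc2cccnc2)[nH]c1=O` keeps the rest of compound 3 and changes one group: pyridin-3-yl in place of 2,4-dimethylphenyl on a saturated chain carbon bound to a sulfur. In words, pyridin-3-yl stands in place of 2,4-dimethylphenyl on a saturated chain carbon bound to a sulfur.

For the measured compounds named here, one measured step touches this same place: a step that the two limits leave unreadable from compound 2 to compound 3. Both of its ends are limits, so it offers no size to carry over to the new change. No step beyond the usual scatter is therefore expected in this assay, and no direction can be favoured. This expectation leans on compound 3, whose reading of > 65000 nM is a limit. The estimated change is an at least 1.0-fold lower number from compound 3 to compound 4 (0.03 log units; that floor lies within the scatter), and the result may well arrive as a limit too. For compound 4 the expected value is 60000 nM, with an estimated range from 25000 nM to 150000 nM.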

Compound 4, half-maximal cytotoxic concentration: > 70000 nM
Compound 4: only a limit was reported (the forecaster's own chance of this, stated with the estimate: 70%); middle value at least 1.1-fold (0.06 log units) from the limit.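

In this assay compound 4 gives > 70000 nM, which is a limit of the assay and not a number. The steps to compound 4 from compound 2 and from compound 3 cannot be read: each joins two limits. As far as these compounds go, whether pyridin-3-yl, 2,4-dimethylphenyl and 4-nitrophenyl differ at all in this test stays open.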